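Fluoro for hydrogen on two related cores, cytotoxicity

This account rests on a few compounds, and the source may have more. Where it says the series, first, only, none or still open, it means among the compounds named here.

Measured compounds in an ADME assay on NCI-H630 cells (Homo sapiens) for cytotoxicity, read by MTT assay, with a stated time of 72 h; on this read-out higher numbers stand for lower toxicity in this test and lower numbers for higher toxicity in this test:
- compound 1 `O=C(O)c1ccc(OCc2ccccc2)cc1O`: a limit of the assay, > 40000 nM
- compound 2 `O=C(O)c1ccc(OCc2ccc(F)cc2)cc1O`: a limit of the assay, > 40000 nM
- compound 3 `O=C(O)c1cc(OCc2ccccc2)ccc1O`: a limit of the assay, > 40000 nM

Compound 1 and compound 2 differ by fluoro in place of hydrogen on an aromatic carbon. The step that the two limits leave unreadable from compound 1 to compound 2 cannot be sized because of the limit of > 40000 nM in this assay, at which 3 of the 3 values shown sit, so the change shows no readable effect here.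

Compound 3 and compound 1 have the same atoms joined differently; the difference between the two cores is not broken down here. Compound 4 `O=C(O)c1cc(OCc2ccc(F)cc2)ccc1O` carries fluoro in place of hydrogen on an aromatic carbon, the same change as that from compound 1 to compound 2, made on the core of compound 3.

The step from compound 3 to compound 4 in this assay is expected to be a step that the limit leaves unreadable from compound 3 to compound 4, an expectation that rests on the limit of > 40000 nM in this assay, at which 3 of the 3 values shown sit, rather than on any readable step. Compound 4 is expected to give 60000 nM, with a range from 40000 nM to 150000 nM, most likely reported again only as a limit.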

Compound 4, half-maximal cytotoxic concentration: > 40000 nM
Compound 4 ended at the assay's limit (the forecaster's own chance of this, stated with the estimate: 90%); the middle value does not contradict the limit.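

No step can be read from compound 3 to compound 4 in this assay, and the step from compound 1 to compound 2 is equally unreadable: the limit of > 40000 nM in this assay, at which 4 of the 4 values shown sit.

The compounds shown leave open whether fluoro in place of hydrogen changes cytotoxicity on either core.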